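This account rests on a few compounds, and the source may have more. Where it says the series, first, only, none or still open, it means among the compounds named here.

Measured compounds in this series:
- compound 1 `Nc1ncn(C[C@@H]2CO[C@H](CO)O2)c(=O)n1`; in a functional assay on P388 cells (Mus musculus) (on this read-out higher numbers stand for an effect only at larger amounts of compound and lower numbers for an effect already at smaller amounts), compound 1 gives 90000 nM
- compound 2 `Nc1ncn(C[C@H]2CO[C@H](CO)O2)c(=O)n1`; in this assay compound 2 gives 65000 nM
- compound 3 `Cc1nn(C[C@@H]2CO[C@H](CO)O2)c(=O)[nH]c1=O`; in this assay compound 3 gives > 100000 nM, which is a limit of the assay and not a number

Compound 3 thus stands at the top of the numbers shown: it is the one value sitting at the limit (the limit of > 100000 nM in this assay, at which 1 of the 3 values shown sits), while compound 1 and compound 2 both carry numbers that lie within the scatter of each other.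

Compound 4 `Cc1nn(C[C@H]2CO[C@@H](CO)O2)c(=O)[nH]c1=O` has not been measured. Its relation to compound 3: the two compounds have the same atoms and bonds and differ only in configuration as drawn: 2 of 2 stereo elements differ (all stereocentres are inverted: mirror images); a stereocentre at a saturated ring carbon is drawn R in compound 3 and S in compound 4; a stereocentre at a saturated ring carbon is drawn S in compound 3 and R in compound 4.

Among the compounds with values here, the one measured step of comparable kind is a 1.4-fold lower number from compound 1 to compound 2 (0.14 log units; within the scatter); it bears on the present step because of the fact that compounds 1 and 2 differ only in the configuration as drawn, though there only one centre was changed and here both are inverted. That step was within the scatter. For compound 3 only a limit is known, so the size of the present step cannot be fixed from the data. The step of a number no higher from compound 3 to compound 4 (the limit leaves the size open) is expected to stay within the scatter. Compound 4 would most likely again be reported only as a limit. Compound 4 in this assay is estimated at 100000 nM, range 30000 nM to 300000 nM.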

Compound 4, half-maximal effective concentration: > 100000 nM
Compound 4 was reported as a limit (the forecaster's own chance of this, stated with the estimate: 65%); the middle value lies on the limit itself.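

In this assay compound 3 gives > 100000 nM, a limit and not a number. Within the data shown here, compound 4 gives > 100000 nM, also a limit, so no step between these mirror images can be read. The compounds shown leave open whether inverting both stereocentres changes the effect at all.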